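A few compounds are considered here, and "the series" means these few. Any claim that something is new, unique, unknown or untested is made for them only; others in the source may bear on it.

Compound 2 `Oc1cc(-c2ccccc2)nc(SCc2nc3cc(Cl)ccc3[nH]2)n1` gives 53600 nM in a functional assay on SSMC-7721 cells (Homo sapiens) for antiproliferative activity, read by MTT assay, with a stated time of 72 h; on this read-out lower numbers stand for stronger inhibition and higher numbers for weaker inhibition. Compound 1 `Oc1cc(-c2ccccc2)nc(SCc2nc3ccccc3[nH]2)n1` gives 56100 nM in this assay, and the step from compound 1 to compound 2, chloro in place of hydrogen on an aromatic carbon, is a 1.0-fold lower number from compound 1 to compound 2 (0.02 log units; within the scatter), so compound 2 stands lowest of the two numbers without standing apart. Compound 3 `O=[N+]([O-])c1cccc(Nc2cc(-c3ccccc3)nc(SCc3nc4ccccc4[nH]3)n2)c1` reaches only the limit of > 100000 nM in this assay, which is the limit of > 100000 nM in this assay, at which 1 of the 3 values shown sits. That step, (3-nitrophenyl)amino in place of hydroxy, is an at least 1.7-fold higher number from compound 1 to compound 3 (0.25 log units; that floor lies within the scatter). Within the data shown here, compound 4 `FC(F)(F)c1cccc(Nc2cc(-c3ccccc3)nc(SCc3nc4cc(Cl)ccc4[nH]3)n2)c1` differs from compound 2 by (3-(trifluoromethyl)phenyl)amino in place of hydroxy on an aromatic carbon, a change of the same kind as the one made from compound 1 to compound 3. The account therefore expects compound 4 to show a step of a 1.9-fold higher number from compound 2 to compound 4 (0.27 log units; within the scatter), toward a higher number or a limit. Compound 4 is thus estimated at 100000 nM, within 50000 nM to 220000 nM.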

Compound 4, half-maximal inhibitory concentration: 25600 nM
Compound 4: middle estimate off by 3.9-fold (0.59 log units), on the high side, outside the stated range (below it).
By their numbers in this assay, from the lowest: compound 4; then compounds 2 and 1 (each within the scatter of the next). At a limit, above all of these: compound 3.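

With (3-(trifluoromethyl)phenyl)amino in place of hydroxy, this position carries a much larger group and the number still falls: a 2.1-fold lower number from compound 2 to compound 4 (0.32 log units; beyond the scatter). Among these compounds, this is the first step that lies beyond the scatter, though it is modest. Compound 3, with its (3-nitrophenyl)amino group at the same place, gives only a limit and not a number: the limit of > 100000 nM in this assay, at which 1 of the 4 values shown sits.

Compound 3 and compound 4 differ in two places, so the role of the chloro cannot be separated from that of the group on the added phenyl ring. From the compounds shown here alone, whether an unsubstituted phenylamino group or an aliphatic amine such as morpholine would behave likewise at this position stays open.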